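The compounds below may be only part of what the source reports. "The series", "measured", "known", "first", "only" and "open" are said of these compounds alone.

Measured so far:
- Compound 1 `CC(C)[C@H](NC(=O)COc1cccc2ccccc12)C(=O)N[C@@H](CC(=O)O)C(=O)COc1ccc(C(N)=O)cc1`: > 100000 nM (a limit of the assay, not a number)
- Compound 2 `CC(C)[C@H](NC(=O)COc1cccc2ccccc12)C(=O)N[C@@H](CC(=O)O)C(=O)COc1ccc(F)c(F)c1F`: 35800 nM

Going by the values given here, in a functional assay on Jurkat cells (Homo sapiens) (on this read-out lower numbers stand for stronger inhibition and higher numbers for weaker inhibition), compound 2 gives 35800 nM, the only true number so far. Compound 3 `CC(C)[C@H](NC(=O)COc1cccc2ccccc12)C(=O)N[C@@H](CC(=O)O)C(=O)COc1c(F)cc(F)cc1F` differs from it in one place: 2,4,6-trifluorophenyl in place of 2,3,4-trifluorophenyl on an oxygen on a saturated carbon. The same atoms stay, joined differently, with 2,4,6-trifluorophenyl in place of 2,3,4-trifluorophenyl. Among the compounds with values here, the one measured step at this place is an at least 2.7-fold lower number from compound 1 to compound 2 (0.44 log units; beyond the scatter), and it swapped in a quite different group. A smaller change is therefore expected here, probably none beyond the scatter, in either direction. The expected step is a 1.4-fold lower number from compound 2 to compound 3 (0.16 log units; within the scatter). Compound 3 is estimated at 25000 nM, with an expected range of 7000 nM to 80000 nM.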

Compound 3, half-maximal inhibitory concentration: 6840 nM
Estimate against measurement, compound 3: 3.7-fold (0.56 log units) above, and the stated range ends above it.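

In this assay, the group on the oxygen matters not only for what it contains but also for how its atoms are arranged: 2,4,6-trifluorophenyl in place of 2,3,4-trifluorophenyl, with the same atoms, gives a 5.2-fold lower number from compound 2 to compound 3 (0.72 log units; beyond the scatter). Against 4-carbamoylphenyl, the same group gives an at least 14-fold lower number from compound 1 to compound 3 (1.16 log units; beyond the scatter). Compound 1 stands at a limit, not a number: the limit of > 100000 nM in this assay, at which 1 of the 3 values shown sits.

From the compounds shown here alone, it remains open which of the fluorine atoms carries the step. Going by these compounds, it is also open whether 2,6-difluorophenyl or 2,4,6-trichlorophenyl would do as well as 2,4,6-trifluorophenyl.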